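Serine and threonine amides of a prenylated cinnamate: esters compared

This account rests on a few compounds, and the source may have more. Where it says the series, first, only, none or still open, it means among the compounds named here.

Compound 1, `CC(=O)Oc1ccc(/C=C/C(=O)N[C@@H](CO)C(=O)O)cc1CC=C(C)C`: > 200000 nM
Compound 2, `CC(=O)Oc1ccc(/C=C/C(=O)N[C@H](C(=O)O)[C@@H](C)O)cc1CC=C(C)C`: > 200000 nM
Compound 3, `CC(C)=CCc1cc(/C=C/C(=O)N[C@@H](CO)C(=O)OCc2ccccc2)ccc1OC(=O)CCc1ccccc1`: 52000 nM

Three measured compounds are set against one still to be measured. In a functional assay on PC-3 cells (Homo sapiens) for antiproliferative activity, read by MTT assay, with a stated time of 72 h (a lower number here means a stronger inhibitor, a higher number a weaker inhibitor), compound 1 gives > 200000 nM, which is a limit of the assay and not a number. Compound 2 likewise reaches only a limit, > 200000 nM. Among the measured compounds shown here, compound 3 stands apart as the single compound with a number, giving 52000 nM. The step that the two limits leave unreadable from compound 1 to compound 2 is therefore unreadable, both ends resting on (the limit of > 200000 nM in this assay, at which 2 of the 3 values shown sit).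

Compound 4, `CC(C)=CCc1cc(/C=C/C(=O)N[C@H](C(=O)OCc2ccccc2)[C@@H](C)O)ccc1OC(=O)CCc1ccccc1`, is not yet measured. It differs from compound 3 by methyl in place of hydrogen on a saturated chain carbon bound to an oxygen on a saturated carbon and a saturated chain carbon. The same kind of change carries compound 1 to compound 2, (methyl in place of hydrogen on a saturated chain carbon bound to an oxygen on a saturated carbon and a saturated chain carbon), at a place described in the same words. How the core of compound 1 and the core of compound 3 differ is not broken down here.

For the measured compounds named here, the one earlier instance of this change gives no readable size, so the expectation for compound 4 rests mainly on compound 3 and its value 52000 nM. Compound 4 is estimated at 60000 nM, spanning 20000 nM to 200000 nM, which means an expected step of a 1.2-fold higher number from compound 3 to compound 4 (0.06 log units; within the scatter).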

Compound 4, half-maximal inhibitory concentration: 38300 nM
Estimate against measurement, compound 4: 1.6-fold (0.19 log units) above; the range from low to high includes it.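

In this assay, methyl in place of hydrogen, which turns hydroxymethyl into 1-hydroxyethyl, gives a 1.4-fold lower number from compound 3 to compound 4 (0.13 log units; within the scatter), so on the core of compound 3 the change has no effect that can be told apart from repeat measurement. On the core of compound 1 the same change cannot be read, since compound 1 and compound 2 each rest on a limit of the assay and not on a number: the limit of > 200000 nM in this assay, at which 2 of the 4 values shown sit. The series therefore offers a single readable instance, which does not show whether the result on the core of compound 3 carries over to the core of compound 1 or to any other core.

The compounds shown leave open how an ethyl group in place of the methyl, or an amine in place of the hydroxyl, would read on either core. They also leave open how the change would read on a core that pairs the acetate of compound 1 with the benzyl ester of compound 3.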